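Replacing the Fluorophenyl Arm with a Branched Alkyl Chain

The compounds below may be only part of what the source reports. "The series", "measured", "known", "first", "only" and "open" are said of these compounds alone.

Compound 1, `N#Cc1ccc(Cc2cnc(CCc3ccc(-c4ccccc4C(=O)O)cc3)[nH]2)cc1`: 723 nM
Compound 2, `O=C(O)c1ccccc1-c1ccc(CCc2ncc(Cc3ccc(F)cc3)[nH]2)cc1`: 50 nM

In an in vitro functional assay on cells for agonist activity at Bombesin receptor subtype-3 (Mus musculus), read by luminescence and calcium flux (a higher number here means that more compound is needed for the effect, a lower number that less compound is needed), compound 2 gives the lowest of the two numbers, and the step of a 14-fold lower number from compound 1 to compound 2 (1.16 log units; beyond the scatter) is the only one measured. Compound 3, `CCC(C)(CC)Cc1cnc(CCc2ccc(-c3ccccc3C(=O)O)cc2)[nH]1`, is not yet measured; it differs from compound 2 by 1-ethyl-1-methylpropyl in place of 4-fluorophenyl on a saturated chain carbon bound to an aromatic carbon. Within the data shown here, the measured step concerns only a swap of substituents on the ring and does not bear on removing the ring itself, so no measured step guides this change. Compound 3 is therefore expected to show a 3.0-fold higher number from compound 2 to compound 3 (0.48 log units; beyond the scatter), with wide uncertainty. The estimate for compound 3 is 150 nM, ranging from 40 nM to 600 nM.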

Compound 3, half-maximal effective concentration: 30 nM
For compound 3 the middle estimate is 5.0-fold (0.70 log units) above the measured one, and the stated range ends above it.
By their numbers in this assay, from the lowest: compounds 3 and 2 (each within the scatter of the next); then compound 1.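

In this assay the step to the ringless group gives a 1.7-fold lower number from compound 2 to compound 3 (0.22 log units; within the scatter) and so shows that the aromatic ring is not required on this saturated chain carbon. Against the nitrile-bearing group, the same 1-ethyl-1-methylpropyl group gives a 24-fold lower number from compound 1 to compound 3 (1.38 log units; beyond the scatter) and thus also stands clear of compound 1. No evidence here accounts for either result. The compounds shown leave open whether a shorter branched chain such as tert-butyl, or a cyclohexyl ring, would serve equally well here. They also leave open how an amine on the chain would fare.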